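Trimming the Piperazine Substituent in a Urotensin-2 Antagonist Series

The compounds below may be only part of what the source reports. "The series", "measured", "known", "first", "only" and "open" are said of these compounds alone.

Compound 2: `COc1ccc([C@@H](CCCN(C)S(=O)(=O)c2cccs2)N2Cc3c(cccc3N3CCN(C4CCC4)CC3)C2=O)cc1OC` gives 4 nM
Compound 1: `CCN1CCN(c2cccc3c2C(=O)N([C@H](CCCNS(=O)(=O)c2cn(C)c(C)n2)c2ccc(OC)c(OC)c2)C3=O)CC1` gives 140 nM

In a functional assay on CHO-K1 cells for antagonist activity at Urotensin-2 receptor (Rattus norvegicus), read by FLIPR and calcium flux, with a stated time of 1 h (on this read-out higher numbers stand for weaker inhibition and lower numbers for stronger inhibition), compound 2 stands at 4 nM, the lowest of the two numbers shown. Compound 1, which differs from it in several places, reaches only 140 nM, a gap beyond the scatter. Compound 3, `COc1ccc([C@@H](CCCN(C)S(=O)(=O)c2cccs2)N2Cc3c(cccc3N3CCN(C)CC3)C2=O)cc1OC`, has not been measured. It differs from compound 2 by methyl in place of cyclobutyl on an amine nitrogen in a ring. For the measured compounds named here, no measured pair isolates this change, so the expectation rests on compound 2 alone. The step of a 2.5-fold higher number from compound 2 to compound 3 (0.40 log units; beyond the scatter) is expected to be a modest weakening, possibly within the scatter. Compound 3 is estimated at 10 nM, with a range of 3 nM to 40 nM.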

Compound 3, half-maximal inhibitory concentration: 16 nM
Estimate against measurement, compound 3: 1.6-fold (0.20 log units) below; low and high end bracket the measured number.
By their numbers in this assay, from the lowest: compound 2; then compound 3; then compound 1.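

In this assay, methyl in place of cyclobutyl on this amine nitrogen in a ring gives a 4.0-fold higher number from compound 2 to compound 3 (0.60 log units; beyond the scatter), the only step shown that isolates this position. The substituent on this nitrogen therefore affects the read-out on its own, and with methyl, compound 3 still gives 16 nM. Nothing measured here accounts for the step. From the compounds shown here alone, what a cyclopentyl group or a plain hydrogen on this nitrogen would give remains open. The ethyl group in compound 1 cannot be read against either, since that compound differs in several places.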